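The source may hold more compounds than are shown below. What is called first, only, known or untested is meant among the compounds shown, and "the series" means these compounds.

Among the measured compounds shown here, compound 2 `O=c1ccoc2cc(OCc3cn(Cc4ccc([N+](=O)[O-])cc4)nn3)ccc12` is the only compound of the pair with a number in a functional assay on HeLa cells (Homo sapiens) for cytotoxicity, read by MTT assay, with a stated time of 48 h (on this read-out higher numbers stand for weaker inhibition and lower numbers for stronger inhibition), where compound 2 gives 25700 nM. Compound 1 `Cc1cccc(Cn2cc(COc3ccc4c(=O)ccoc4c3)nn2)c1` returns only a limit of the assay, > 100000 nM, in this assay. For the measured compounds named here, the single measured step, an at least 3.8-fold lower number from compound 1 to compound 2 (0.59 log units; beyond the scatter), is the only guide available, and it rests on a limit of > 100000 nM in this assay, at which 1 of the 2 values shown sits, rather than on two numbers.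

Compound 3 `COc1ccc(Cn2cc(COc3ccc4c(=O)ccoc4c3)nn2)cc1` differs from compound 2 by methoxy in place of nitro on an aromatic carbon. The measured step swaps a whole aryl group at a different position, so it bears on this change only loosely; it shows that the group at this position can move the number beyond the scatter, but not how methoxy compares with nitro. The number for compound 3 is therefore expected to sit somewhat higher than that of compound 2, with wide uncertainty, an estimated step of a 2.3-fold higher number from compound 2 to compound 3 (0.37 log units; beyond the scatter). Compound 3 is estimated at 60000 nM, with a range from 20000 nM to 150000 nM.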

Compound 3, half-maximal inhibitory concentration: 14400 nM
For compound 3 the middle estimate is 4.2-fold (0.62 log units) above the measured one; the whole stated range lies above it.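

In this assay, the change on this aromatic carbon, para to a large group, gives a 1.8-fold lower number from compound 2 to compound 3 (0.25 log units; within the scatter), so nitro and methoxy cannot be told apart here. The earlier pair showed only that replacing the whole aryl group could move the number, whereas this pair shows that two quite different groups at this place leave it within the scatter. Against 3-methylphenyl, 4-methoxyphenyl gives an at least 6.9-fold lower number from compound 1 to compound 3 (0.84 log units; beyond the scatter), and this step, like the earlier one, rests on a limit and not on two numbers: the limit of > 100000 nM in this assay, at which 1 of the 3 values shown sits.

The compounds shown do not separate the place of the group from its identity, as 3-methylphenyl differs from the other two aryl groups in both. They also leave open how an amine, a carboxylic acid or a chlorine atom on that aromatic carbon would read.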